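The source may hold more compounds than are shown below. What is called first, only, known or untested is meant among the compounds shown, and "the series" means these compounds.

Compound 1, `CCC1(Cc2ccccc2)OS(=O)(=O)C=C1OCC1CCCCC1`, was tested in an ADME assay on HEL cells (Homo sapiens) for cytotoxicity, with a stated time of 3 days (a higher number here means that more compound is tolerated, a lower number that less compound is tolerated), where it gives > 200000 nM; this is a limit of the assay rather than a measured number, as the limit of > 200000 nM in this assay, at which 1 of the 3 values shown sits, records. Two related compounds have been measured alongside it. Compound 2, `CCC1(Cc2ccccc2)OS(=O)(=O)C=C1NCc1ccccc1`, gives 92000 nM in this assay. Compound 3, `CCC1(CC)OS(=O)(=O)C=C1OCc1ccccc1`, gives 200000 nM in this assay. Among the measured compounds shown here, the only step between compounds that differ in a single place is an at least 2.1-fold lower number from compound 1 to compound 2 (0.33 log units; beyond the scatter). Compound 4, `CCC1(Cc2ccccc2)OS(=O)(=O)C=C1OCc1ccc(C)cc1`, has not yet been measured. It differs from compound 1 in one place: 4-methylphenyl in place of cyclohexyl on a saturated chain carbon bound to an oxygen on an unsaturated carbon. For the measured compounds named here, no measured step alters this same part of the molecule, so the step from compound 1 to compound 2, which changes a different group, offers no direct guide. Compound 3 differs from compound 1 in two places rather than one, so only its value can be set beside the others, and it lies at the high end of what has been seen. On this footing no step beyond the scatter is expected in this assay, and the expected step is a number no higher from compound 1 to compound 4 (the limit leaves the size open). Compound 4 is therefore expected to give about 200000 nM, with a likely range from 100000 nM to 400000 nM, and a real chance that only a limit is reported again.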

Compound 4, half-maximal cytotoxic concentration: 41500 nM
The estimate for compound 4 lay 4.8-fold (0.68 log units) above the measured number; measured number below the stated range.
By their numbers in this assay, from the lowest: compound 4; then compound 2; then compound 3.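

Among the compounds shown here, this result is the first to show that the outer end of the side chain on oxygen matters in this assay, since the earlier step changed a different group. Exchanging cyclohexyl for 4-methylphenyl on a saturated chain carbon bound to an oxygen on an unsaturated carbon, with the rest of the molecule unchanged, gives an at least 4.8-fold lower number from compound 1 to compound 4 (0.68 log units; beyond the scatter), so less compound is tolerated and this place is not indifferent to the ring it carries. Because compound 1 stands at a limit rather than at a measured number, this step has only a lower bound and its true size may be larger: the limit of > 200000 nM in this assay, at which 1 of the 4 values shown sits.

The change swaps a saturated ring for an aromatic one and adds a methyl at the same time, so the compounds shown leave open which of the two carries the step; a plain phenyl or a 4-methylcyclohexyl in this place would separate them. They also leave open how the number would respond to a ring carrying an amine or a carboxylic acid, or to a longer chain at this place.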